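A few compounds are considered here, and "the series" means these few. Any claim that something is new, unique, unknown or untested is made for them only; others in the source may bear on it.

Measured so far:
compound 1 `COc1ccc(-c2csc3nc(-c4cc(F)c(Cl)cc4Cl)nn23)cc1` — 40.6%
compound 2 `Cc1ccc(-c2csc3nc(-c4cc(F)c(Cl)cc4Cl)nn23)cc1` — 0%
compound 3 `Fc1ccc(-c2csc3nc(-c4cc(F)c(Cl)cc4Cl)nn23)cc1` — 48.8%

In a functional assay on the whole organism (strain Wister albino) for inhibition, with Rattus norvegicus as the target, read by paw edema, with stated times of 30 min and 3 h, at a dose of 50 mg/kg by the oral route (a lower number here means less inhibition, a higher number more inhibition at the dose given (going by the name of the read-out)), compound 3 stands highest of the three numbers. Its nearest neighbour is compound 1, the step of a number 8.2 percentage points higher from compound 1 to compound 3 (within the scatter) being within the scatter, and its furthest is compound 2, with the step of a number 48.8 percentage points higher from compound 2 to compound 3 (beyond the scatter) being large. Among the compounds with values here, the step of a number 40.6 percentage points lower from compound 1 to compound 2 (beyond the scatter) shows how much the read-out can fall when only this group is exchanged.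

Compound 4 `Fc1cc(-c2nc3scc(-c4ccc(Br)cc4)n3n2)c(Cl)cc1Cl` differs from compound 3 by bromo in place of fluoro on an aromatic carbon. Within the data shown here, no measured step exchanges one halogen for another, so the bearing steps are only those at the same site: a number 8.2 percentage points higher from compound 1 to compound 3 (within the scatter) and a number 48.8 percentage points higher from compound 2 to compound 3 (beyond the scatter). They show that a change here can leave the number almost unchanged or collapse it altogether, so a step of either direction is possible. Compound 4 is estimated at 38%, in a range from 5% to 60%, which is expected to mean a number 10.8 percentage points lower from compound 3 to compound 4 (beyond the scatter).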

Compound 4, a percentage reported as inhibition, in the whole organism at one dose (the size of the read-out at that dose, not a potency): 25%
Compound 4: the middle estimate sits 13 percentage points above what was measured; the measured number falls inside the stated range.
By their numbers in this assay, from the lowest: compound 2; then compound 4; then compounds 1 and 3 (each within the scatter of the next).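

In this assay, the change from 4-fluorophenyl to 4-bromophenyl is the only exchange of one halogen for another shown at this position, and it gives a number 23.8 percentage points lower from compound 3 to compound 4 (beyond the scatter), so the two halogens do not read alike here. Bromo also stands apart from the other two groups, with a number 15.6 percentage points lower from compound 1 to compound 4 (beyond the scatter) on one side and a number 25 percentage points higher from compound 2 to compound 4 (beyond the scatter) on the other, which shows that this position can hold an intermediate level as well as values near the top and none at all. Being a halogen does not by itself set the number, as methoxy in compound 1 stands within the scatter of fluoro in compound 3.

As far as these compounds go, how chloro, an amine or a carboxylic acid would read at this place remains open. Nothing at hand explains these steps.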